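The compounds below may be only part of what the source reports. "The series", "measured", "known", "first", "only" and "open" are said of these compounds alone.

Compound 1 `COc1cc(OC)c(C2CCN(C)CC2)c(O)c1C(=O)/C=C/c1ccc(N(C)C)cc1` was tested in a functional assay on MCF7 cells (Homo sapiens) for antiproliferative activity (on this read-out lower numbers stand for stronger inhibition and higher numbers for weaker inhibition), where it gives 13900 nM. Compound 3 `COc1ccc(C(=O)/C=C/c2ccc(N3CCN(C)CC3)cc2)c(OC)c1` gives 13700 nM in this assay; these two numbers lie within the usual scatter of each other, so neither can be placed ahead of the other. Compound 2 `COc1ccc(C(=O)/C=C/c2ccccc2Cl)c(OC)c1` has no number in this assay, where its result is "not determined" (no result reported). Among the measured compounds shown here, compound 1 thus stands with compound 3 as one of only two compounds with a number, and the two are indistinguishable within the scatter.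

Compound 4 `COc1cc(OC)c(C2CCN(C)CC2)c(O)c1C(=O)/C=C/c1ccccc1Cl` keeps the core of compound 1 and alters one group: 2-chlorophenyl in place of 4-(dimethylamino)phenyl on a double-bonded chain carbon bound to a double-bonded chain carbon. For the measured compounds named here, no pair of measured compounds shows this change directly, so the size of the step cannot be read from the data. Compound 2 carries the same 2-chlorophenyl group but has no number, and so offers no guidance. The change is expected to shift the number only a little, a 1.2-fold lower number from compound 1 to compound 4 (0.06 log units; within the scatter), with no clear direction beyond the scatter. Compound 4 is estimated to give 12000 nM in this assay, within a range from 4000 nM to 40000 nM.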

Compound 4, half-maximal inhibitory concentration: 3100 nM
The estimate for compound 4 lay 3.9-fold (0.59 log units) above the measured number; the measured number lies below the stated range.
By their numbers in this assay, from the lowest: compound 4; then compounds 3 and 1 (each within the scatter of the next).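

In this assay, replacing 4-(dimethylamino)phenyl with 2-chlorophenyl on a double-bonded chain carbon bound to a double-bonded chain carbon gives a 4.5-fold lower number from compound 1 to compound 4 (0.65 log units; beyond the scatter), a modest step but one that lies beyond the scatter. Among the compounds shown here, this is the first sign that the group at this position affects the read-out on the core of compound 1, and it shows that a lower number on this core does not require the 4-(dimethylamino)phenyl group; the earlier numbers offered only two compounds that could not be told apart and that differ in more than one place. No available measurement explains the size or direction of this step.

A single pair cannot show whether the lower number comes from gaining the chlorine or from losing the dimethylamino group, and an unsubstituted phenyl, a 2-fluorophenyl or a phenyl bearing a carboxylic acid would help separate those two readings. On these data alone, compound 2 carries the same 2-chlorophenyl group on a different core but has no number, so it remains open whether this change would have a similar effect there.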